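This account rests on a few compounds, and the source may have more. Where it says the series, first, only, none or still open, it means among the compounds named here.

Compound 2, `CC(=O)Nc1cc(C)n(Cc2cc(Cl)ccc2OCc2ccccc2)n1`: 316 nM
Compound 1, `Cc1cc(C(=O)NN2CCCCC2)nn1Cc1cc(Cl)ccc1OCC(C)C`: 200 nM

In an assay on CHO-K1 cells for displacement of a labelled ligand from prostaglandin E2 receptor EP1 subtype (Homo sapiens) (on this read-out higher numbers stand for weaker inhibition and lower numbers for stronger inhibition), compound 2 gives 316 nM and compound 1 gives 200 nM. These two numbers lie within the usual scatter of each other, so neither compound can be set apart from the other; compound 2 simply stands alongside compound 1 on this read-out. Compound 3, `Cc1cc(NC(=O)OCc2ccccn2)nn1Cc1cc(Cl)ccc1OCc1ccccc1`, has not yet been measured in this assay. It differs from compound 2 in one place: (pyridin-2-yl)methoxy in place of methyl on a carbonyl carbon. Within the data shown here, no measured pair shows this kind of change, so its effect is not known from the two compounds in hand. The expected step of a 2.1-fold lower number from compound 2 to compound 3 (0.32 log units; beyond the scatter) is a modest move toward a lower number, one that may well remain within the scatter of repeated measurements. On that basis compound 3 is estimated at 150 nM, with a range from 40 nM to 600 nM.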

Compound 3, half-maximal inhibitory concentration: 79.4 nM
Estimate against measurement, compound 3: 1.9-fold (0.28 log units) above; the range from low to high includes it.
By their numbers in this assay, from the lowest: compound 3; then compounds 1 and 2 (each within the scatter of the next).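

In this assay, among these compounds, replacing the methyl on a carbonyl carbon, whose other neighbour is an amide-type nitrogen, with (pyridin-2-yl)methoxy gives a 4.0-fold lower number from compound 2 to compound 3 (0.60 log units; beyond the scatter), the first step in this set that can be read as a single change. It shows that this position accepts far more than a methyl: acetamido becomes (((pyridin-2-yl)methoxy)carbonyl)amino, and binding strengthens rather than being lost. The change brings in an oxygen and a six-membered aromatic ring with one hetero atom together, so this one step cannot assign the gain to either part.

A plain methoxy or a dimethylamino group on the same carbonyl carbon would help show how much of the gain depends on the ring. No measurement shown here explains why the number falls with this change.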